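Aryl swap on the shared core: compound 3 outlook

This account rests on a few compounds, and the source may have more. Where it says the series, first, only, none or still open, it means among the compounds named here.

Within the data shown here, in an assay for inhibition of histone deacetylase 4 (Homo sapiens) (a lower number here means a stronger inhibitor, a higher number a weaker inhibitor), compound 1 `O=C(c1ccc(-c2nc(-c3ccccn3)no2)s1)C(F)(F)F` gives 90 nM, the lowest of the two numbers known so far. Compound 2 `O=C(c1ccc(-c2nc(-c3cccc(C(F)(F)F)c3)no2)s1)C(F)(F)F` gives 320 nM in this assay, a weaker result than compound 1 by a margin beyond the scatter. Compound 3 `O=C(c1ccc(-c2nc(-c3ccc(F)cc3F)no2)s1)C(F)(F)F` is not yet measured and carries 2,4-difluorophenyl in place of pyridin-2-yl on an aromatic carbon. Among the measured compounds shown here, no measured pair covers this change directly. Compound 2 also carries a six-membered aromatic ring of carbon only and gives 320 nM. On that basis a modest loss is expected, with a 2.4-fold higher number from compound 1 to compound 3 (0.39 log units; beyond the scatter) pointing to a higher number. Compound 3 is therefore estimated at 220 nM, within 80 nM to 600 nM.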

Compound 3, half-maximal inhibitory concentration: 120 nM
Beside the measured number, compound 3's estimate is 1.8-fold (0.26 log units) above it; the range from low to high includes it.
By their numbers in this assay, from the lowest: compounds 1 and 3 (each within the scatter of the next); then compound 2.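

In this assay there is a 1.3-fold higher number from compound 1 to compound 3 (0.12 log units; within the scatter) for 2,4-difluorophenyl in place of pyridin-2-yl on this aromatic carbon, so the ring nitrogen of pyridin-2-yl is not needed here to keep the number of compound 1. A six-membered aromatic ring of carbon only, with 0 hydrogen-bond acceptors, therefore fits this position without a step beyond the scatter. No available evidence bears on this result.

Still open, from the compounds shown here alone, is how an amine or a carboxylic acid on the aryl ring would read at this position. Going by these compounds, a non-aromatic ring such as piperidine on this carbon is equally open.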